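Methyl in Place of Bromo: Expectation for Compound 3

The source may hold more compounds than are shown below. What is called first, only, known or untested is meant among the compounds shown, and "the series" means these compounds.

Compound 2 `O=C(Nc1cccc(/C=C/C(=O)c2nc3ccccc3[nH]2)c1)c1cccc(Br)c1` gives 5210 nM in a functional assay on MCF7 cells (Homo sapiens) for antiproliferative activity, read by MTT assay, with a stated time of 48 h (a higher number here means a weaker inhibitor, a lower number a stronger inhibitor), the lowest of the two numbers shown, while compound 1 `O=C(Nc1cccc(/C=C/C(=O)c2nc3ccccc3[nH]2)c1)c1ccccc1` gives 11200 nM. Within the data shown here, the only step available is a 2.1-fold lower number from compound 1 to compound 2 (0.33 log units; beyond the scatter). Compound 3 `Cc1cccc(C(=O)Nc2cccc(/C=C/C(=O)c3nc4ccccc4[nH]3)c2)c1` differs from compound 2 by methyl in place of bromo on an aromatic carbon. Among the measured compounds shown here, no measured step exchanges bromo for methyl, so only that modest step bears on the question, and it gives no reason to expect a large move in either direction. Compound 3 is therefore expected to change little, with a 1.2-fold higher number from compound 2 to compound 3 (0.10 log units; within the scatter) expected to fall within the scatter. The estimate for compound 3 is 6500 nM, between 3000 nM and 14000 nM.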

Compound 3, half-maximal inhibitory concentration: 5590 nM
The estimate for compound 3 lay 1.2-fold (0.07 log units) above the measured number; low and high end bracket the measured number.
By their numbers in this assay, from the lowest: compounds 2, 3 and 1 (each within the scatter of the next, the first and the last beyond it).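

In this assay, methyl in place of bromo gives a 1.1-fold higher number from compound 2 to compound 3 (0.03 log units; within the scatter), so 3-bromophenyl and 3-methylphenyl cannot be told apart at this position. Methyl in place of hydrogen gives a 2.0-fold lower number from compound 1 to compound 3 (0.30 log units; within the scatter), a step that stays within the scatter, whereas the step from hydrogen to bromo lay just beyond it. Nothing available explains why these two groups read alike. On these data alone, whether an amine or a carboxylic acid at this position would read differently stays open, as does the effect of a longer chain there.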